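Adding a Hydroxy Group: From Compound 3 to Compound 4

This account rests on a few compounds, and the source may have more. Where it says the series, first, only, none or still open, it means among the compounds named here.

Measured compounds:
Compound 1 `O=C(/C=C/c1ccc(O)cc1)N1CCCC1` gives 3.51%
Compound 2 `O=C(/C=C/c1ccc(O)c(O)c1)N1CCCC1` gives 83.2%
Compound 3 `O=C(/C=C/c1ccc(O)cc1)N1CCCCC1` gives 0.91%

Of the compounds shown here, three have been measured in a functional assay, with a stated time of 30 min, tested at 1 mM; on this read-out lower numbers stand for less inhibition and higher numbers for more inhibition at the one concentration tested (going by the name of the read-out). Compound 3 stands lowest of the three numbers. Its nearest neighbour is compound 1, whose number is higher by an amount within the scatter, so the two cannot be told apart. Its furthest is compound 2, which lies well beyond the scatter above it.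

Compound 4 `O=C(/C=C/c1ccc(O)c(O)c1)N1CCCCC1` has not yet been measured. It differs from compound 3 by hydroxy in place of hydrogen on an aromatic carbon. Going by the values given here, one measured step bears directly on this change: a number 79.7 percentage points higher from compound 1 to compound 2 (beyond the scatter). That step is the same change in words, made on the core of compound 1, and it was large and clearly beyond the scatter.

Compound 3 and compound 1 sit together at the low end, so the analogous change from compound 3 is expected to produce a step of comparable size and the same direction. The estimated step is a number 77.1 percentage points higher from compound 3 to compound 4 (beyond the scatter) in this assay. For compound 4 the expected value is 78%, within a range from 55% to 95%. Among the compounds with values here, only one such step is available, so the range is kept wide.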

Compound 4, a percentage reported as inhibition, at one concentration (the size of the read-out at that concentration, not a potency): 82.9%
Compound 4: the middle estimate sits 4.9 percentage points below what was measured, and the stated range covers the measured number.
By their numbers in this assay, from the lowest: compounds 3 and 1 (each within the scatter of the next); then compounds 4 and 2 (each within the scatter of the next).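

In this assay, hydroxy in place of hydrogen on an aromatic carbon, ortho to a hydroxy group, gives a number 82 percentage points higher from compound 3 to compound 4 (beyond the scatter), so the gain no longer rests on a single core. The size of the change also carries over from one core to the other: the same change on two cores in this assay, a number 79.7 percentage points higher (beyond the scatter) from compound 1 to compound 2 and a number 82 percentage points higher (beyond the scatter) from compound 3 to compound 4, 2.3 percentage points apart, within the scatter of two such steps With this hydroxy group present, piperidin-1-yl in place of pyrrolidin-1-yl on a carbonyl carbon gives a number 0.3 percentage points lower from compound 2 to compound 4 (within the scatter); this is a new reading of that swap, since the earlier pair lay at the low end, where compound 1 gives 3.51% and compound 3 gives 0.91%.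

The compounds shown leave open whether a methoxy group, a fluorine atom or an amine on the same aromatic carbon would give a similar number, and whether an open-chain group such as diethylamino on the carbonyl carbon would match piperidin-1-yl and pyrrolidin-1-yl. Since each number comes from one concentration, they also leave open how compound 2 and compound 4 would compare in potency.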